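Removing a Chloro Group from a Pair at the Assay Limit

A few compounds are considered here, and "the series" means these few. Any claim that something is new, unique, unknown or untested is made for them only; others in the source may bear on it.

Compound 1, `Fc1ccc(-c2cn3nc(Cc4ccc(Cl)cc4)sc3n2)cc1`, gives > 250000 nM in a functional assay on HeLa cells (Homo sapiens) for cytotoxicity, with a stated time of 72 h (a lower number here means a stronger inhibitor, a higher number a weaker inhibitor), which is a limit of the assay rather than a number. Compound 2, `Clc1ccc(Cc2nn3c(Br)c(-c4ccc(Cl)cc4)nc3s2)cc1`, gives > 250000 nM in this assay, again a limit and not a number.

Compound 2 therefore stands at the limit of > 250000 nM in this assay, at which 2 of the 2 values shown sit, and both values shown so far are limits, so no ordering between compound 1 and compound 2 can be read from them. Compound 3, `Clc1ccc(Cc2nn3c(Br)c(-c4ccccc4)nc3s2)cc1`, differs from compound 2 in one place: hydrogen in place of chloro on an aromatic carbon. Among the compounds with values here, no measured step between two compounds is available to guide a prediction, so the expectation rests only on where compound 2 sits. Compound 3 is expected to give 250000 nM, with a range from 60000 nM to 1000000 nM, most likely reported again as a limit. The expected step is a number no higher from compound 2 to compound 3 (the limit leaves the size open), that is, none beyond the scatter.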

Compound 3, half-maximal inhibitory concentration: > 250000 nM
Compound 3 gave a limit, no number; the forecaster's own chance of this, stated with the estimate: 80%; the middle value lies on the limit itself.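

Compound 2 and compound 3 both give a limit rather than a number, so no step can be read between them, and the change from 4-chlorophenyl to phenyl shows no readable result: the limit of > 250000 nM in this assay, at which 3 of the 3 values shown sit.

The compounds shown leave open what number, if any, each would give in this assay and whether this change matters at all.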